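The source may report more compounds than this note shows. Statements on the series, on what has been measured and on what is new or still open speak of the compounds shown alone.

Compound 3 `CCOC(=O)c1cnc(C2CC2)nc1NN1C(=O)C=C(C)C1=O` carries a cyclopropyl group on the shared core and, in a functional assay on Jurkat cells for inhibition of nuclear factor NF-kappa-B complex (Homo sapiens) (a lower number here means a stronger inhibitor, a higher number a weaker inhibitor), gives 1000 nM. Among the three measured compounds it stands second highest. Its nearest neighbour is compound 2 `CCOC(=O)c1cnc(-c2ccc(Cl)cc2)nc1NN1C(=O)C=C(C)C1=O`, which in this assay gives 300 nM, so that a 3.3-fold higher number from compound 2 to compound 3 (0.52 log units; beyond the scatter). Furthest from it is compound 1 `CCOC(=O)c1cnc(-n2nc(C)cc2C)nc1NN1C(=O)C=C(C)C1=O`, which gives 10000 nM, and a 10-fold lower number from compound 1 to compound 3 (1.00 log units; beyond the scatter). Those two outer compounds are separated by a larger step, as a 33-fold lower number from compound 1 to compound 2 (1.52 log units; beyond the scatter).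

Compound 4 `CCOC(=O)c1cnc(Sc2ccccc2)nc1NN1C(=O)C=C(C)C1=O` arises from compound 3 by the change (phenylsulfanyl in place of cyclopropyl on an aromatic carbon). For the measured compounds named here, two measured steps bear on this exchange of the cyclopropyl group for a larger ring-bearing group: the six-membered carbon ring of compound 2 gave a modestly lower number than the cyclopropyl of compound 3, whereas the pyrazolyl ring of compound 1 gave a clearly higher one. Since the entering group, like 4-chlorophenyl, brings a six-membered aromatic ring of carbon only, a modest move toward a lower number is expected, a 2.0-fold lower number from compound 3 to compound 4 (0.30 log units; within the scatter). Compound 4 is therefore estimated at 500 nM, with a likely range from 150 nM to 2000 nM.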

Compound 4, half-maximal inhibitory concentration: 1000 nM
The estimate for compound 4 lay 2.0-fold (0.30 log units) below the measured number, within the range that was stated.
By their numbers in this assay, from the lowest: compound 2; then compounds 3 and 4 (each within the scatter of the next); then compound 1.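

On the aromatic carbon between two ring nitrogen atoms, a six-membered aromatic ring of carbon only does not by itself go with the lower number: phenylsulfanyl and cyclopropyl cannot be told apart (no change at the digits printed from compound 3 to compound 4 (within the scatter)), although the entering group has more heavy atoms and a sulfur atom. The phenylsulfanyl group still falls short of 4-chlorophenyl (a 3.3-fold higher number from compound 2 to compound 4 (0.52 log units; beyond the scatter)), yet it keeps clear of the 3,5-dimethyl-1H-pyrazol-1-yl group (a 10-fold lower number from compound 1 to compound 4 (1.00 log units; beyond the scatter)), so compound 2 alone holds the lowest number among these four. No measurement shown here accounts for these differences. The compounds shown leave open whether the sulfur link or the chlorine separates compound 4 from compound 2, a question that a plain phenyl group or a 4-chlorophenylsulfanyl group would address. They also leave open how an amine such as morpholine at this carbon would compare.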